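Swapping Bromo for Methoxy on a Cyclopropylmethyl Core

The compounds below may be only part of what the source reports. "The series", "measured", "known", "first", "only" and "open" are said of these compounds alone.

Three compounds have been measured in an ADME assay on microsomes from liver (Rattus norvegicus, strain Wistar) for metabolic stability, tested at 2.5 uM; on this read-out higher numbers stand for fast clearance and lower numbers for slow clearance:
Compound 1 `Brc1cccc2c1nnn2CC1CC1` gives 0.6 mL/min/g.
Compound 2 `CC(C)Cn1nnc2c(Br)cccc21` gives 4 mL/min/g.
Compound 3 `Brc1cc(Br)c2nnn(CC3CC3)c2c1` gives 2.3 mL/min/g.

Compound 1 stands lowest of the three numbers, and both steps away from it are beyond the scatter. The step of a 3.8-fold higher number from compound 1 to compound 3 (0.58 log units; beyond the scatter) came with bromo in place of hydrogen on an aromatic carbon, and the step of a 6.7-fold higher number from compound 1 to compound 2 (0.82 log units; beyond the scatter) with isopropyl in place of cyclopropyl on a saturated chain carbon bound to an aromatic nitrogen. Each is a modest rise in this assay; each touches a different part of the shared core.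

Compound 4 `COc1cccc2c1nnn2CC1CC1` has not yet been measured. It differs from compound 1 as follows: methoxy in place of bromo on an aromatic carbon. Going by the values given here, neither measured step removes the bromo or places a methoxy, so nothing measured here bears directly on this change; the data give no comparable step. What they do show is that both single changes made so far to compound 1 moved the number upward by a modest amount. Among the compounds with values here, with that as the only guide, compound 4 is expected to show a rise of similar size, a 2.5-fold higher number from compound 1 to compound 4 (0.40 log units; beyond the scatter), giving an estimated 1.5 mL/min/g with a range from 0.5 mL/min/g to 4.5 mL/min/g.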

Compound 4, intrinsic clearance in a liver preparation (reported as CLH), per the amount of preparation that the assay uses: 0.8 mL/min/g
The estimate for compound 4 lay 1.9-fold (0.27 log units) above the measured number; the measured number falls inside the stated range.
By their numbers in this assay, from the lowest: compounds 1 and 4 (each within the scatter of the next); then compounds 3 and 2 (each within the scatter of the next).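

In this assay, methoxy in place of bromo on an aromatic carbon gives a 1.3-fold higher number from compound 1 to compound 4 (0.12 log units; within the scatter), so at this position the swap produces no change that can be told apart from the usual spread of repeated measurements. This sets it apart from the two earlier single changes, bromo in place of hydrogen on an aromatic carbon and isopropyl in place of cyclopropyl on the chain, which both gave rises beyond the scatter; here, methoxy brings a hydrogen-bond acceptor that bromo lacks, yet the read-out does not separate the two compounds. No supporting measurement is available to explain this result.

The compounds shown leave open whether other groups at this position, such as an amine or a carboxylic acid, would also stay within the scatter of compound 1, as bromo and methoxy are the only groups seen there. They also leave open whether the same swap would hold on compound 2, since methoxy appears here only on the core that carries the cyclopropylmethyl chain.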